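Swapping 2,4-dihydroxyphenyl for 3-bromo-4-hydroxyphenyl

This account rests on a few compounds, and the source may have more. Where it says the series, first, only, none or still open, it means among the compounds named here.

Measured so far in a functional assay on HepG2 cells (Homo sapiens) for antiproliferative activity, read by MTT assay, with a stated time of 72 h; a lower number here means a stronger inhibitor, a higher number a weaker inhibitor:
Compound 1 `O=C(N/N=C/c1ccc(Br)cc1)Nc1ccc(Oc2ccnc3[nH]ccc23)c(F)c1`: 1000 nM
Compound 2 `O=C(N/N=C/c1ccc([N+](=O)[O-])cc1)Nc1ccc(Oc2ccnc3[nH]ccc23)c(F)c1`: 3030 nM
Compound 3 `O=C(N/N=C/c1ccc(O)cc1O)Nc1ccc(Oc2ccnc3[nH]ccc23)c(F)c1`: 4550 nM

Compound 3 shares the high end of these numbers with compound 2. That pair is separated only by a 1.5-fold higher number from compound 2 to compound 3 (0.18 log units; within the scatter), so the two cannot be told apart. Only compound 1 lies clearly lower.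

Compound 4 `O=C(N/N=C/c1ccc(O)c(Br)c1)Nc1ccc(Oc2ccnc3[nH]ccc23)c(F)c1` has not yet been measured. It differs from compound 3 in one place: 3-bromo-4-hydroxyphenyl in place of 2,4-dihydroxyphenyl on a carbon with a double bond to nitrogen.

Going by the values given here, two measured steps bear on this change, and both lead away from the bromine-bearing ring: a 3.0-fold higher number from compound 1 to compound 2 (0.48 log units; beyond the scatter) and a 4.6-fold higher number from compound 1 to compound 3 (0.66 log units; beyond the scatter). Both are modest. Compound 4 regains a bromine, as carried by compound 1 at 1000 nM, but it also keeps a hydroxy group, as compound 3 does at 4550 nM. Only part of that gap is therefore expected to close. In this assay, a modest step to a lower number is expected, and it may not stand far beyond the scatter.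

For compound 4, the expected step is a 2.1-fold lower number from compound 3 to compound 4 (0.32 log units; beyond the scatter).

Compound 4 is estimated at 2200 nM, with an expected range of 800 nM to 6000 nM.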

Compound 4, half-maximal inhibitory concentration: 1360 nM
The estimate for compound 4 lay 1.6-fold (0.21 log units) above the measured number, within the range that was stated.
By their numbers in this assay, from the lowest: compounds 1 and 4 (each within the scatter of the next); then compounds 2 and 3 (each within the scatter of the next).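

In this assay, the two compounds with a bromine on this ring now read alike, and a hydroxy group on the ring does not by itself set the number: compound 4 keeps one, yet a 1.4-fold higher number from compound 1 to compound 4 (0.13 log units; within the scatter) leaves it indistinguishable from the bromo compound without one. The two compounds without bromine both stand clearly apart from compound 4, with a 3.3-fold lower number from compound 3 to compound 4 (0.52 log units; beyond the scatter) and a 2.2-fold lower number from compound 2 to compound 4 (0.35 log units; beyond the scatter), so among these four compounds the presence of bromine on the ring goes with the lower numbers, and no compound here goes against that. This is only a link within four compounds, and no measurement is available to explain it.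

The compounds shown leave open how much of the step from the 2,4-dihydroxyphenyl ring belongs to the incoming bromine and how much to the outgoing hydroxy group, a question that a plain 4-hydroxyphenyl ring would help to separate. Also open, as far as these compounds go, is whether bromine itself matters or whether another group at the same place, such as chlorine, a methyl group or an amine, would read the same.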